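Half-life of a trifluoromethylphenyl analogue on rat liver microsomes

This account rests on a few compounds, and the source may have more. Where it says the series, first, only, none or still open, it means among the compounds named here.

Compound 1 `O=C(NCCCCN1CCN(c2ccccc2)CC1)c1ccc(-c2ccsc2)cc1`: 0.41 h in an ADME assay on microsomes from liver (Rattus norvegicus) for metabolic stability, read by LC-MS, using NADPH; on this read-out higher numbers stand for a longer-lived compound and lower numbers for a shorter-lived compound
Compound 2 `O=C(NCCCCN1CCN(c2ccc(Cl)cc2)CC1)c1ccc(-c2ccsc2)cc1`: 0.837 h in this assay
Compound 3 `O=C(NCCCCN1CCN(c2ccccc2O)CC1)c1ccc(-c2ccsc2)cc1`: 0.157 h in this assay

Compound 3 stands lowest of the three numbers in this assay. Its nearest neighbour is compound 1, which differs by a 2.6-fold lower number from compound 1 to compound 3 (0.42 log units; beyond the scatter); its furthest is compound 2, from which it differs by a 5.3-fold lower number from compound 2 to compound 3 (0.73 log units; beyond the scatter). The unmeasured compound 4 `O=C(NCCCCN1CCN(c2cccc(C(F)(F)F)c2)CC1)c1ccc(-c2ccsc2)cc1` differs from compound 3 in one place: 3-(trifluoromethyl)phenyl in place of 2-hydroxyphenyl on an amine nitrogen in a ring.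

Within the data shown here, two measured steps bear on this change. The hydroxy group that leaves is the group whose arrival gave a 2.6-fold lower number from compound 1 to compound 3 (0.42 log units; beyond the scatter), so taking it away is expected to undo that drop. Among the measured compounds shown here, the group that enters has no direct precedent, but the nearest comparison, a substituent on the same phenyl ring, gave a 2.0-fold higher number from compound 1 to compound 2 (0.31 log units; beyond the scatter). A rise in this assay is therefore expected for compound 4, of about a 3.8-fold higher number from compound 3 to compound 4 (0.58 log units; beyond the scatter), bringing compound 4 close to compounds 1 and 2. Compound 4 is estimated at 0.6 h, with a likely range of 0.25 h to 1.5 h.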

Compound 4, half-life: 0.282 h
Compound 4: the middle estimate sits 2.1-fold (0.33 log units) above what was measured; the range from low to high includes it.
By their numbers in this assay, from the lowest: compounds 3, 4 and 1 (each within the scatter of the next, the first and the last beyond it); then compound 2.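

In this assay, the 3-(trifluoromethyl)phenyl group on the ring nitrogen gives a 1.5-fold lower number from compound 1 to compound 4 (0.16 log units; within the scatter), so compound 4 cannot be told apart from compound 1, which carries a plain phenyl group there. Replacing 2-hydroxyphenyl gives a 1.8-fold higher number from compound 3 to compound 4 (0.25 log units; within the scatter), again no clear difference, while a 3.0-fold lower number from compound 2 to compound 4 (0.47 log units; beyond the scatter) shows that the higher number seen with 4-chlorophenyl does not carry over to 3-(trifluoromethyl)phenyl, so a substituent on this phenyl ring does not raise the number in every case. Nothing available here explains these numbers.

The compounds shown leave open whether the number follows the group itself or its place on the phenyl ring, since chloro and trifluoromethyl stand at different places. A methoxy group or a nitrile on that ring would show how far the number can move.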